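The source may report more compounds than this note shows. Statements on the series, on what has been measured and on what is new or still open speak of the compounds shown alone.

Measured so far in a functional assay on HCT-116 cells (Homo sapiens) for antiproliferative activity, read by MTT assay, with a stated time of 48 h; on this read-out lower numbers stand for stronger inhibition and higher numbers for weaker inhibition:
Compound 1 `COc1ccc(-c2cc3c(cn2)[nH]c(=O)n3-c2cc(OC)c(OC)c(OC)c2)cc1F` gives 910 nM.
Compound 2 `CCOc1ccc(-c2cc3c(cn2)[nH]c(=O)n3-c2cc(OC)c(OC)c(OC)c2)cc1F` gives 7220 nM.
Compound 3 `CCn1c(=O)n(-c2cc(OC)c(OC)c(OC)c2)c2cc(-c3ccc(OC)c(O)c3)ncc21` gives > 20000 nM, which is a limit of the assay and not a number (the limit of > 20000 nM in this assay, at which 1 of the 3 values shown sits).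

The step of a 7.9-fold higher number from compound 1 to compound 2 (0.90 log units; beyond the scatter) corresponds to methyl in place of hydrogen on a saturated chain carbon bound to an oxygen on an aromatic ring. The difference between the cores of compound 1 and compound 3 is not broken down here.

Compound 4 `COc1ccc(-c2cc3c(cn2)n(C(C)C)c(=O)n3-c2cc(OC)c(OC)c(OC)c2)cc1O` is not yet measured. It differs from compound 3 by methyl in place of hydrogen on a saturated chain carbon bound to an aromatic nitrogen and a saturated chain carbon. This is the same kind of change as from compound 1 to compound 2, but not the same: there the place is a saturated chain carbon bound to an oxygen on an aromatic ring, here a saturated chain carbon bound to an aromatic nitrogen and a saturated chain carbon. The earlier step of a 7.9-fold higher number from compound 1 to compound 2 (0.90 log units; beyond the scatter) weakened activity. Compound 3 already sits at the limit (the limit of > 20000 nM in this assay, at which 1 of the 3 values shown sits). Compound 4 is therefore expected to give 40000 nM, probably reported again as a limit, with a range of 15000 nM to 150000 nM. The expected step is a step that the limit leaves unreadable from compound 3 to compound 4, resting on the direction of the earlier step.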

Compound 4, half-maximal inhibitory concentration: 6660 nM
Compound 4: middle estimate off by 6.0-fold (0.78 log units), on the high side; measured number outside the range, below it.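

In this assay compound 3 gives > 20000 nM, a limit of the assay and not a number, so its step can be read only as a bound. Ethyl to isopropyl gives an at least 3.0-fold lower number from compound 3 to compound 4 (0.47 log units; beyond the scatter), so the direction of the methyl change did not carry over from the earlier core: the same change on two cores in this assay, a 7.9-fold higher number (0.90 log units; beyond the scatter) from compound 1 to compound 2 and an at least 3.0-fold lower number (0.47 log units; beyond the scatter) from compound 3 to compound 4, at least 23-fold (1.37 log units) apart, beyond the scatter of two such steps

This does not show whether the core or the place of the change sets the two steps apart: both differ, and each core offers a single pair.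

Still open, as far as these compounds go, is how a longer chain, such as n-butyl, or a cyclopropyl group at this place would read on the core of compound 4.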